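A few compounds are considered here, and "the series" means these few. Any claim that something is new, unique, unknown or untested is made for them only; others in the source may bear on it.

Compound 1 `Cc1c(C(=O)Nc2c(F)cc(-c3cccc(F)c3)cc2F)nc2ccc(F)cc2c1O` and compound 2 `CCOc1ccc2nc(C(=O)Nc3c(F)cc(-c4cccc(F)c4)cc3F)c(C)c(O)c2c1` share one core and differ only at the aromatic carbon where compound 1 carries fluoro and compound 2 carries ethoxy. In a functional assay on A-375 cells (Homo sapiens) for antiproliferative activity, read by MTT assay, with a stated time of 24 h, tested at 1.23 ug/mL (on this read-out lower numbers stand for a weaker effect and higher numbers for a stronger effect at the one concentration tested), compound 1 gives 2.34%, and in this assay compound 2 gives 2.96%. Among the measured compounds shown here, the single measured step, a number 0.6 percentage points higher from compound 1 to compound 2 (within the scatter), shows that the two numbers cannot be ranked against each other; both sit near the bottom of the percentage scale, and compound 2 has no standing of its own beyond that.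

Compound 3 `Cc1c(C(=O)Nc2c(F)cc(-c3cccc(F)c3)cc2F)nc2ccc(C(F)(F)F)cc2c1O` differs from compound 2 by trifluoromethyl in place of ethoxy on an aromatic carbon. For the measured compounds named here, the only step that bears on this change is a number 0.6 percentage points higher from compound 1 to compound 2 (within the scatter), at the same position and within the scatter; it gives no ground to expect a shift beyond the scatter in this assay for compound 3 either. Compound 3 is therefore expected to give 3% in this assay, with a range of 0% to 12%. The estimated step is a number 0 percentage points higher from compound 2 to compound 3 (within the scatter).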

Compound 3, a percentage reported as inhibition, at one concentration (the size of the read-out at that concentration, not a potency): 21.3%
The estimate for compound 3 lay 18.3 percentage points below the measured number; the whole stated range lies below it.
By their numbers in this assay, from the lowest: compounds 1 and 2 (each within the scatter of the next); then compound 3.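

At this aromatic carbon, the series does respond to the group placed there in this assay: trifluoromethyl in place of ethoxy gives a number 18.3 percentage points higher from compound 2 to compound 3 (beyond the scatter), and trifluoromethyl in place of fluoro gives a number 19 percentage points higher from compound 1 to compound 3 (beyond the scatter). The fluoro-to-ethoxy pair alone showed no movement beyond the scatter, so the position could have seemed insensitive; the two new steps show that it is not, with compound 3 standing clear of both compound 1 and compound 2. Nothing at hand accounts for the difference between trifluoromethyl and the other two groups.

The three groups shown leave open whether the higher number is specific to trifluoromethyl or extends to groups such as chloro, nitrile, an amine or a carboxylic acid. On these data alone, the read-out at one concentration gives the size of an effect, so the potency of compound 3 also stays open.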